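The source may report more compounds than this note shows. Statements on the series, on what has been measured and on what is new or still open speak of the compounds shown alone.

Three amides built on the shared core were measured in an assay on SH-EP1 cells for agonist activity at Neuronal acetylcholine receptor; alpha4/beta2 (Homo sapiens), read by FLIPR and calcium flux; on this read-out lower numbers stand for an effect already at smaller amounts and higher numbers for an effect only at larger amounts of compound. Compound 1 `O=C(C1CCC1)N1CC2CC(C1)N2` gives 11000 nM. Compound 2 `O=C(C1CCCC1)N1CC2CC(C1)N2` gives 29000 nM, and compound 3 `O=C(CC1C=CCC1)N1CC2CC(C1)N2` gives 37000 nM. Compound 1 therefore stands lowest of the three, and both of the other numbers lie beyond the usual scatter of this assay, compound 2 by a step of moderate size and compound 3 by a somewhat larger one. Among these three compounds the smaller acyl group goes with the lower number.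

Compound 4 `C[C@@H]1C[C@@H]1C(=O)N1CC2CC(C1)N2` has not yet been measured. It differs from compound 1 in one place: a group of 4 heavy atoms (4 carbon; one three-membered non-aromatic ring of carbon only) in place of a group of 4 heavy atoms (4 carbon; one four-membered non-aromatic ring of carbon only), on a carbonyl carbon, so the atom count at the carbonyl carbon is unchanged while the ring shrinks from four members to three and carries a methyl with two defined stereocentres.

Because compound 1 gives 11000 nM and the smaller acyl groups have given the lower numbers, compound 4 is expected to lie close to compound 1 or somewhat lower. The expected step of a 1.4-fold lower number from compound 1 to compound 4 (0.14 log units; within the scatter) is small, with no confident direction beyond the scatter. The estimate for compound 4 in this assay is 8000 nM, between 3000 nM and 25000 nM.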

Compound 4, half-maximal effective concentration: 3800 nM
Compound 4: middle estimate off by 2.1-fold (0.32 log units), on the high side, and the stated range covers the measured number.
By their numbers in this assay, from the lowest: compound 4; then compound 1; then compounds 2 and 3 (each within the scatter of the next).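

In this assay, replacing cyclobutyl with the methyl-carrying three-membered ring on the carbonyl carbon gives a 2.9-fold lower number from compound 1 to compound 4 (0.46 log units; beyond the scatter), a modest change. This shows that the number at this position can move with no change in the count of heavy atoms in the group, something compounds 1, 2 and 3, whose acyl groups differ in size, could not show. Nothing measured here accounts for the step.

The compounds shown leave open whether the lower number of compound 4 belongs to the smaller ring, to its methyl or to its two defined stereocentres. Going by these compounds, how a plain cyclopropyl group, the mirror-image form of compound 4 or a ring carrying an amine would read also remains open.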